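A Single Fluoro Added to an Unsubstituted Phenyl Sulfone

The source may report more compounds than this note shows. Statements on the series, on what has been measured and on what is new or still open speak of the compounds shown alone.

Three closely related compounds share one core and differ only in the fluorine on the phenyl ring of the sulfone, or on the core itself. Compound 1 `O=S(=O)(c1cccc(F)c1)c1cn(C2CCNC2)c2cc(F)ccc12` carries two fluoro groups, but for compound 1 the entry reads "not determined" (no result reported), so no result was reported. Compound 2 `O=S(=O)(c1ccccc1)c1cn(C2CCNC2)c2ccccc12` carries none. In a functional assay on HeLa cells for agonist activity at 5-hydroxytryptamine receptor 6 (Homo sapiens), read by cAMP accumulation and immunoassay, with a stated time of 10 min (on this read-out higher numbers stand for larger maximal responses and lower numbers for smaller maximal responses), compound 2 gives 70%, and this is the only number shown in the whole set, so compound 2 is the sole point of reference here.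

Compound 3 `O=S(=O)(c1cccc(F)c1)c1cn(C2CCNC2)c2ccccc12` is the next step from compound 2, and the change is fluoro in place of hydrogen on an aromatic carbon. Nothing else in the molecule moves. Within the data shown here, no measured pair with this kind of change is available for comparison, so there is no step size to lean on. With only a single fluoro entering on the phenyl ring, the change is expected to be small, in either direction, and most likely not beyond the usual scatter; the step of no change at the digits printed from compound 2 to compound 3 (within the scatter) is the estimate for that. Compound 3 is therefore expected to give about 70% in this assay, with a plausible range from 50% to 90%.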

Compound 3, largest response reached (Emax), in percent of the reference or control that the assay uses: 38%
Beside the measured number, compound 3's estimate is 32 percentage points above it, outside the stated range (below it).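

Going from phenyl to 3-fluorophenyl, this assay shows a number 32 percentage points lower from compound 2 to compound 3 (beyond the scatter), the first step available in this set. It shows that this place on the ring, meta to a large group, is not indifferent to what sits there: a single fluorine atom in place of hydrogen is enough to shift the maximal response, although compound 3 still gives 38% and the response does not vanish. Nothing in the available data explains why one fluoro has so large an effect.

The compounds shown leave open whether this drop is specific to fluoro or would also follow from another group at the same place, such as chloro, methoxy or an amine, and whether fluoro elsewhere on the ring would give the same result. For compound 1, which carries a second fluoro on the shared core, the entry reads "not determined" (no result reported), so the effect of that further fluoro on the response of compound 3 also remains an open question.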